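Amide in place of ketone on the hexyloxy chain

The source may report more compounds than this note shows. Statements on the series, on what has been measured and on what is new or still open speak of the compounds shown alone.

Measured so far:
compound 1, `C=CCc1cc(C(C)=O)c(O)cc1OCCCCCC`, gives 9%;
compound 2, `C=CCc1cc(C(C)=O)c(O)cc1OCCCCCC(C)=O`, gives 58%.

Both were tested in an assay on isolated protein for binding affinity to leukotriene B4 receptor 1 (Homo sapiens), tested at 1 uM; on this read-out lower numbers stand for less inhibition and higher numbers for more inhibition at the one concentration tested (going by the name of the read-out). Compound 2 stands higher of the two, and the step from the first to the second, a number 49 percentage points higher from compound 1 to compound 2 (beyond the scatter), is large: it replaces a methyl with an acetyl on a saturated chain carbon, five bonds along the chain from an oxygen on an aromatic ring. Compound 3, `C=CCc1cc(C(C)=O)c(O)cc1OCCCCCC(=O)N(C)C`, takes this chain one move further: dimethylamino in place of methyl on a carbonyl carbon. Within the data shown here, no measured step changes the group on that carbonyl carbon, so the step from compound 1 to compound 2 is the only one that bears on it, and it speaks only to adding the carbonyl, not to what sits on it. The expectation for compound 3 is therefore a small step, a number 3 percentage points lower from compound 2 to compound 3 (within the scatter), with wide uncertainty in either direction. Compound 3 is estimated at 55%, between 25% and 80%.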

Compound 3, a percentage reported as inhibition, at one concentration (the size of the read-out at that concentration, not a potency): 54%
The estimate for compound 3 lay 1 percentage points above the measured number; the measured number falls inside the stated range.
By their numbers in this assay, from the lowest: compound 1; then compounds 3 and 2 (each within the scatter of the next).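

Dimethylamino in place of methyl on a carbonyl carbon gives a number 4 percentage points lower from compound 2 to compound 3 (within the scatter) and so leaves the ketone of compound 2 and the amide of compound 3 indistinguishable in this test. Set against the plain hexyloxy chain, dimethylcarbamoyl in place of methyl gives a number 45 percentage points higher from compound 1 to compound 3 (beyond the scatter) and shows that the large gain first seen with acetyl is not limited to a ketone, and that this carbonyl carbon can carry the larger dimethylamino group. Nothing available explains why these chain ends behave alike.

The compounds shown leave open whether the carbonyl itself is required, which a chain ending in a hydroxyl group could test. From the compounds shown here alone, how a carboxylic acid, a primary amide or a longer chain would compare also remains unknown.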